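Methyl in place of fluoro on the fused aromatic ring

The source may report more compounds than this note shows. Statements on the series, on what has been measured and on what is new or still open speak of the compounds shown alone.

In a functional assay on the whole organism with Rattus norvegicus as the target, at a dose of 20 mg/kg by the oral route (a lower number here means less inhibition, a higher number more inhibition at the dose given (going by the name of the read-out)), compound 1 `NC(=O)/C=C1\CCc2c(F)cccc21` gives 34%. Compound 2 `COc1ccc2c(c1)CC/C2=C\C(N)=O` gives 25% in this assay, a number within the scatter of compound 1, so the two cannot be told apart. Compound 3 `O=C(/C=C1\CCc2ccc(F)cc21)NC1CCC1` gives 0% in this assay, a number beyond the scatter below compound 1. Compound 1 thus sits alongside compound 2 and clearly apart from compound 3.

Compound 4 `Cc1cccc2c1CC/C2=C\C(N)=O` differs from compound 1 by methyl in place of fluoro on an aromatic carbon. For the measured compounds named here, no measured pair shares this change, so no measured step guides the estimate. The expected step of a number 4 percentage points lower from compound 1 to compound 4 (within the scatter) is small, within the scatter, with no direction favoured. Compound 4 is expected to give 30% in this assay, with an estimated range from 10% to 50%.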

Compound 4, a percentage reported as inhibition, in the whole organism at one dose (the size of the read-out at that dose, not a potency): 13%
Estimate against measurement, compound 4: 17 percentage points above, and the stated range covers the measured number.
By their numbers in this assay, from the lowest: compound 3; then compound 4; then compounds 2 and 1 (each within the scatter of the next).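

Methyl in place of fluoro on an aromatic carbon gives a number 21 percentage points lower from compound 1 to compound 4 (beyond the scatter) in this assay, the first step in the series that changes a single place. This position is therefore sensitive to the exchange of one heavy atom for another, and fluoro and methyl are not interchangeable here, although one pair sets no trend. Nothing available explains the step.

As far as these compounds go, whether hydrogen, chloro or an amine on this carbon would read closer to compound 1 or to compound 4 remains open. Also open, from the compounds shown here alone, is whether the same exchange has a similar effect elsewhere on the aromatic ring.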